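Aryl ether variation on the shared core: compound 3

The compounds below may be only part of what the source reports. "The series", "measured", "known", "first", "only" and "open" are said of these compounds alone.

Measured so far:
compound 1 `COc1ccccc1Oc1cncc(C2=CC3CNCC(C2)C3)c1` — an in vitro assay on SH-SY5Y cells for displacement of a labelled ligand from Neuronal acetylcholine receptor; alpha3/beta4 (Homo sapiens); on this read-out lower numbers stand for stronger inhibition and higher numbers for weaker inhibition: 56 nM
compound 2 `Clc1cccc(Oc2cncc(C3=CC4CNCC(C3)C4)c2)c1` — this assay: 22 nM

Going by the values given here, compound 2 holds the lowest of the two numbers; its only neighbour is compound 1, separated by a 2.5-fold lower number from compound 1 to compound 2 (0.41 log units; beyond the scatter), a modest step beyond the scatter.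

Compound 3 `COc1ccc(Oc2cncc(C3=CC4CNCC(C3)C4)c2)cc1` differs from compound 2 by 4-methoxyphenyl in place of 3-chlorophenyl on an oxygen on an aromatic ring. Among the compounds with values here, the one step that bears on this is a 2.5-fold lower number from compound 1 to compound 2 (0.41 log units; beyond the scatter), where a methoxyphenyl gave way to the chlorophenyl and the number fell. The present change removes that chlorophenyl for a methoxyphenyl again, though the 4-methoxyphenyl entering here is not the 2-methoxyphenyl of compound 1, so the earlier step is only a rough guide. A modest rise in this assay is therefore expected, of about the size seen before, with wide uncertainty.

Compound 3 is estimated at 40 nM in this assay, within 15 nM to 110 nM. This estimate means a step of a 1.8-fold higher number from compound 2 to compound 3 (0.26 log units; within the scatter).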

Compound 3, inhibition constant: 27 nM
The estimate for compound 3 lay 1.5-fold (0.17 log units) above the measured number, and the stated range covers the measured number.
By their numbers in this assay, from the lowest: compounds 2 and 3 (each within the scatter of the next); then compound 1.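

In this assay, 4-methoxyphenyl in place of 3-chlorophenyl on an oxygen on an aromatic ring gives a 1.2-fold higher number from compound 2 to compound 3 (0.09 log units; within the scatter), so these two groups cannot be told apart on this read-out, and a methoxyphenyl at this place does not in itself go with the higher number of compound 1. The comparison between the two methoxyphenyl groups, 4-methoxyphenyl in place of 2-methoxyphenyl, gives a 2.1-fold lower number from compound 1 to compound 3 (0.32 log units; beyond the scatter), a modest step that shows the two isomeric groups are not equivalent here and leaves compound 1 apart from both other compounds. Nothing at hand explains these numbers.

From the compounds shown here alone, whether a 4-chlorophenyl or a 3-methoxyphenyl would stay level with compound 2 and compound 3 remains open. So does the outcome for a phenyl ring carrying an amine or a carboxylic acid.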